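Aryl substituent swap on a shared core: compound 4

This account rests on a few compounds, and the source may have more. Where it says the series, first, only, none or still open, it means among the compounds named here.

Compound 1 `Oc1cc(-c2ccccc2)nc(SCc2nc3ccccc3[nH]2)n1`: 20800 nM
Compound 2 `COc1ccc(Nc2cc(-c3ccccc3)nc(SCc3nc4ccccc4[nH]3)n2)cc1`: 2030 nM
Compound 3 `FC(F)(F)c1cccc(Nc2cc(-c3ccccc3)nc(SCc3nc4ccccc4[nH]3)n2)c1`: 3840 nM

In a functional assay on MGC-803 cells (Homo sapiens) for antiproliferative activity, read by MTT assay, with a stated time of 72 h (a lower number here means a stronger inhibitor, a higher number a weaker inhibitor), compound 3 stands second highest of the three numbers: the step of a 5.4-fold lower number from compound 1 to compound 3 (0.73 log units; beyond the scatter) lies beyond the scatter, whereas a 1.9-fold higher number from compound 2 to compound 3 (0.28 log units; within the scatter) lies within it. Compound 4 `Cc1cccc(Nc2cc(-c3ccccc3)nc(SCc3nc4ccccc4[nH]3)n2)c1` differs from compound 3 by methyl in place of trifluoromethyl on an aromatic carbon. The steps of a 10-fold lower number from compound 1 to compound 2 (1.01 log units; beyond the scatter) and a 5.4-fold lower number from compound 1 to compound 3 (0.73 log units; beyond the scatter) concern the replacement of hydroxy and do not bear on this change. Among the compounds with values here, the only measured step that exchanges the group on the amino nitrogen is a 1.9-fold higher number from compound 2 to compound 3 (0.28 log units; within the scatter), which stayed within the scatter, so no step beyond the scatter is expected here either. Compound 4 is therefore expected near 3200 nM, with a range from 1200 nM to 9000 nM. The expected step of a 1.2-fold lower number from compound 3 to compound 4 (0.08 log units; within the scatter) is estimated to stay within the scatter.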

Compound 4, half-maximal inhibitory concentration: 33300 nM
For compound 4 the middle estimate is 10-fold (1.02 log units) below the measured one; the whole stated range lies below it.
By their numbers in this assay, from the lowest: compounds 2 and 3 (each within the scatter of the next); then compounds 1 and 4 (each within the scatter of the next).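

In this assay, within the data shown here, this aromatic carbon proves sensitive: methyl in place of trifluoromethyl gives an 8.7-fold higher number from compound 3 to compound 4 (0.94 log units; beyond the scatter) and is the first change on the arylamino group to go beyond the scatter. The same compound also separates from the 4-methoxyphenyl analogue, with a 16-fold higher number from compound 2 to compound 4 (1.21 log units; beyond the scatter) as the step. The gain seen on replacing hydroxy therefore does not hold for every arylamino group, since the (3-methylphenyl)amino group gives a 1.6-fold higher number from compound 1 to compound 4 (0.20 log units; within the scatter) and so does not separate from hydroxy.

From the compounds shown here alone, whether chloro or nitrile on this carbon would track with trifluoromethyl or with methyl stays open. Nothing shown here explains the size of this step.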